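Aminopyrimidine series, thiophene amide tail: phenyl to benzyl

The source may hold more compounds than are shown below. What is called first, only, known or untested is meant among the compounds shown, and "the series" means these compounds.

Three compounds from the series have been characterised in an assay on isolated protein for inhibition of serine/threonine-protein kinase TBK1 (Homo sapiens); on this read-out higher numbers stand for weaker inhibition and lower numbers for stronger inhibition. Compound 2 `O=C(NCCCNc1nc(Nc2cccc(F)c2)ncc1Br)c1cccs1` gives 9 nM. Compound 3 `O=C(NCCCNc1nc(Nc2ccccc2F)ncc1C1CC1)c1cccs1` gives 820 nM, the higher of the two numbers obtained so far; the gap between compound 2 and compound 3 is well beyond the scatter. For the measured compounds named here, for compound 1 `CC(C)c1cnc(Nc2cccc(F)c2)nc1NCCCNC(=O)C1CCC1` this assay returns only a limit, > 1000 nM, not a number; this is the one value that sits at the limit of > 1000 nM in this assay, at which 1 of the 3 values shown sits.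

The next compound, compound 4 `O=C(NCCCNc1nc(NCc2ccc(F)cc2)ncc1C1CC1)c1cccs1`, is derived from compound 3 by a single change: 4-fluorobenzyl in place of 2-fluorophenyl on a nitrogen on an aromatic ring. Going by the values given here, no pair that differs only in this position has been measured, so the size of the step has no direct precedent. The change moves the aromatic ring out by one methylene and shifts the fluorine round the ring, and the nearest comparator, compound 3, already gives a high number. The step from compound 3 to compound 4 is expected to be upward, a 2.4-fold higher number from compound 3 to compound 4 (0.39 log units; beyond the scatter), and a number may not be reached at all. Compound 4 is therefore estimated at 2000 nM, with a plausible range from 400 nM to 10000 nM.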

Compound 4, half-maximal inhibitory concentration: > 10000 nM
Compound 4: only a limit was reported; the forecaster's own chance of this, stated with the estimate: 55%; middle value at least 5.0-fold (0.69 log units) away from the limit.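

In this assay compound 4 gives only a limit, > 10000 nM, not a number: the limit of > 10000 nM in this assay, at which 1 of the 4 values shown sits. For the compounds shown here, compounds 3 and 4 form the first pair that differs in one place, and the step from (2-fluorophenyl)amino to (4-fluorobenzyl)amino is large, an at least 12-fold higher number from compound 3 to compound 4 (1.08 log units; beyond the scatter), showing that inhibition in this assay responds strongly to the group on this nitrogen. The change combines an added methylene with a different fluorine position, and this single pair does not separate the two.

As far as these compounds go, it remains open how much of the step belongs to the methylene and how much to the fluorine position. A plain benzyl or a plain phenyl on the same nitrogen would bear on that question.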